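A few compounds are considered here, and "the series" means these few. Any claim that something is new, unique, unknown or untested is made for them only; others in the source may bear on it.

Four compounds built around an amino-linked aromatic core are compared here in a functional assay on Bel-7402 cells (Homo sapiens) for cytotoxicity, read by MTT assay; on this read-out higher numbers stand for weaker inhibition and lower numbers for stronger inhibition. Compound 1 `Cc1ccccc1Nc1nc(C)c(C(=O)/C=C/c2ccccc2)s1` carries a 2-methylphenyl on a nitrogen on an aromatic ring. In this assay compound 1 reaches only a limit of the assay, > 25000 nM. Compound 2 `Cc1cccc(Nc2nc(C)c(C(=O)/C=C/c3ccccc3)s2)c1` differs from compound 1 in one place: 3-methylphenyl in place of 2-methylphenyl on a nitrogen on an aromatic ring. In this assay compound 2 likewise reaches only a limit of the assay, > 25000 nM. The step that the two limits leave unreadable from compound 1 to compound 2 therefore cannot be sized, which follows from the limit of > 25000 nM in this assay, at which 2 of the 3 values shown sit.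

Compound 3 `COc1cc(/C=C/C(=O)c2sc(Nc3ccccc3C)nc2C)cc(OC)c1OC` has a different core; how the core of compound 3 differs from the core of compound 1 is not broken down here. In this assay, within the data shown here, compound 3 gives 10300 nM, the only actual number among the three measured values.

Compound 4 `COc1cc(/C=C/C(=O)c2sc(Nc3cccc(C)c3)nc2C)cc(OC)c1OC` has not yet been measured. It differs from compound 3 by 3-methylphenyl in place of 2-methylphenyl on a nitrogen on an aromatic ring, the same change that separates compound 1 from compound 2, and at the same place. That earlier step left no readable size, so it offers no guide to the direction of the change. Compound 3, with its value of 10300 nM in this assay, is thus the sole basis of what is expected next. The step of a 1.2-fold higher number from compound 3 to compound 4 (0.07 log units; within the scatter) is expected to stay within the usual scatter of this assay. Compound 4 is estimated at 12000 nM in this assay, with a plausible range from 5000 nM to 30000 nM.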

Compound 4, half-maximal inhibitory concentration: > 25000 nM
Compound 4: only a limit was reported; the forecaster's own chance of this, stated with the estimate: 35%; at least 2.0-fold (0.31 log units) between middle value and limit.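

On the core of compound 3, putting 3-methylphenyl in place of 2-methylphenyl on a nitrogen on an aromatic ring gives an at least 2.4-fold higher number from compound 3 to compound 4 (0.38 log units; beyond the scatter) in this assay, so on this core the change weakens inhibition by more than repeat measurements would scatter. Going by these compounds, compound 4 gives > 25000 nM, which is a limit of the assay and not a number, so the step has only a smallest size and its full size stays unknown. The same change on the core of compound 1 cannot be read, so nothing here shows whether it acts alike on the two cores, and one readable step on one core does not establish a rule for the series, because of how many values stop at the same limit: the limit of > 25000 nM in this assay, at which 3 of the 4 values shown sit.

On these data alone, compound 3 alone gives an actual number, 10300 nM, so it remains open whether another group on that nitrogen, such as an unsubstituted phenyl or a phenyl carrying an amine or a carboxylic acid, would give a lower number than compound 3 does. Also open, as far as these compounds go, is whether the step seen here would recur on any further core, where values might fall clear of the limit and both ends of the step could be read.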